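Swapping the Ring on the Amide Carbonyl

This account rests on a few compounds, and the source may have more. Where it says the series, first, only, none or still open, it means among the compounds named here.

Compound 1 `COc1cccc(C(=O)Nc2cnn(Cc3c(C)noc3C)c2)n1` and compound 2 `COc1ccc(C(=O)Nc2cnn(Cc3c(C)noc3C)c2)cc1` share one core and differ only in the group on a carbonyl carbon. In a functional assay on cells for antagonist activity at taste receptor type 2 member 8 (Homo sapiens), read by FLIPR and calcium flux, with a stated time of 100 s (on this read-out higher numbers stand for weaker inhibition and lower numbers for stronger inhibition), compound 1 gives 700 nM and compound 2 gives 700 nM; the step of no change at the digits printed from compound 1 to compound 2 (within the scatter) shows that this exchange left the read-out unmoved. Compound 3 `Cc1noc(C)c1Cn1cc(NC(=O)c2ccccc2O)cn1` has not yet been measured; it differs from compound 1 by 2-hydroxyphenyl in place of 6-methoxypyridin-2-yl on a carbonyl carbon. Only the flat step no change at the digits printed from compound 1 to compound 2 (within the scatter) bears on this change, so the expected step of no change at the digits printed from compound 1 to compound 3 (within the scatter) is none beyond the scatter. Compound 3 is therefore estimated at 700 nM, with a range from 250 nM to 2000 nM.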

Compound 3, half-maximal inhibitory concentration: 1000 nM
Compound 3: the middle estimate sits 1.4-fold (0.15 log units) below what was measured; measured number inside the range.
By their numbers in this assay, from the lowest: compounds 1, 2 and 3 (each within the scatter of the next).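

On the carbonyl carbon, 2-hydroxyphenyl brings a hydrogen-bond donor that 6-methoxypyridin-2-yl lacks, yet this assay records a 1.4-fold higher number from compound 1 to compound 3 (0.15 log units; within the scatter) and also a 1.4-fold higher number from compound 2 to compound 3 (0.15 log units; within the scatter) and so this position has now held three different six-membered aromatic rings with no step beyond the scatter. Nothing in the data at hand explains this flat result. On these data alone, a ring carrying an amine or a carboxylic acid, or a longer chain in place of the ring, remains open here. Whether any group at this position can move the number beyond the scatter also stays unanswered.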